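Adding a hydroxy group to compound 2

A few compounds are considered here, and "the series" means these few. Any claim that something is new, unique, unknown or untested is made for them only; others in the source may bear on it.

compound 1 `COc1ccc(/C=C/C(=O)c2ccccc2-c2ccc(F)cc2)cc1O`: 500 nM
compound 2 `COc1ccc(/C=C/C(=O)c2ccccc2-c2cccc(F)c2)cc1`: 860 nM

Among the compounds with values here, in a functional assay on A2780 cells (Homo sapiens) for antiproliferative activity, read by sulforhodamine B assay, with a stated time of 48 h (a higher number here means a weaker inhibitor, a lower number a stronger inhibitor), compound 2 at 860 nM lies within the scatter of compound 1 at 500 nM, the only other measured compound. Compound 3 `COc1ccc(/C=C/C(=O)c2ccccc2-c2cccc(F)c2)cc1O` differs from compound 2 by hydroxy in place of hydrogen on an aromatic carbon. Within the data shown here, no measured pair isolates this change, so the expectation is tentative: a small move toward stronger inhibition, near the edge of the scatter. Compound 1, which also carries a hydroxy group, stands at 500 nM. The expected change is a 2.2-fold lower number from compound 2 to compound 3 (0.33 log units; beyond the scatter). For compound 3 the estimated value is 400 nM, with an expected range of 100 nM to 1100 nM.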

Compound 3, half-maximal inhibitory concentration: 230 nM
Estimate against measurement, compound 3: 1.7-fold (0.24 log units) above; the measured number falls inside the stated range.
By their numbers in this assay, from the lowest: compound 3; then compounds 1 and 2 (each within the scatter of the next).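

In this assay the hydroxy group ortho to a methoxy group now has its own measured step, a 3.7-fold lower number from compound 2 to compound 3 (0.57 log units; beyond the scatter), and it is a modest gain. With that hydroxy group in place, 3-fluorophenyl in place of 4-fluorophenyl also counts, giving a 2.2-fold lower number from compound 1 to compound 3 (0.34 log units; beyond the scatter). Nothing measured here explains either step.

As far as these compounds go, whether an amine or a chlorine atom on the same aromatic carbon would match hydroxy remains open. So does the size of the hydroxy step on the 4-fluorophenyl series.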